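A few compounds are considered here, and "the series" means these few. Any claim that something is new, unique, unknown or untested is made for them only; others in the source may bear on it.

Compound 1 `Cc1ccc2[nH]c(-c3ccc(-c4ccc(-c5ccc(N(C)C)cc5)cc4)cc3)nc2c1` and compound 2 `Cc1ccc2[nH]c(-c3ccc(-c4ccc(-c5cccc(Cl)c5)cc4)cc3)nc2c1` share one core, while compound 3 `CN(C)c1ccc(-c2ccc(-c3ccc(-c4nc5c(O)cccc5[nH]4)cc3)cc2)cc1` carries another. In a functional assay on A549 cells (Homo sapiens) for inhibition, read by sulforhodamine B assay (a higher number here means a weaker inhibitor of growth, a lower number a stronger inhibitor of growth), compound 1 gives 3510 nM, compound 2 gives 2800 nM and compound 3 gives 7100 nM. The change 3-chlorophenyl in place of 4-(dimethylamino)phenyl on an aromatic carbon produced a 1.3-fold lower number from compound 1 to compound 2 (0.10 log units; within the scatter). The two cores differ by 4-hydroxy-1H-benzimidazol-2-yl in place of 5-methyl-1H-benzimidazol-2-yl on an aromatic carbon, a change that produced a 2.0-fold higher number from compound 1 to compound 3 (0.31 log units; beyond the scatter). Compound 4 `Oc1cccc2[nH]c(-c3ccc(-c4ccc(-c5cccc(Cl)c5)cc4)cc3)nc12` has not been measured yet; it differs from compound 3 by 3-chlorophenyl in place of 4-(dimethylamino)phenyl on an aromatic carbon, the same change at the same place as between the first two compounds. Since that change earlier gave only a 1.3-fold lower number from compound 1 to compound 2 (0.10 log units; within the scatter), the expected step from compound 3 to compound 4 is a 1.3-fold lower number from compound 3 to compound 4 (0.11 log units; within the scatter). Compound 4 is therefore expected to give about 5500 nM in this assay, most likely between 2500 nM and 12000 nM.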

Compound 4, concentration for 50% growth inhibition: 2400 nM
Compound 4: the middle estimate sits 2.3-fold (0.36 log units) above what was measured; measured number outside the range, below it.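

In this assay, putting 3-chlorophenyl in place of 4-(dimethylamino)phenyl gives a 3.0-fold lower number from compound 3 to compound 4 (0.47 log units; beyond the scatter). Going by these compounds alone, although only this step lies beyond the scatter on its own, the gap between it and the earlier step does not: the same change on two cores in this assay, a 1.3-fold lower number (0.10 log units; within the scatter) from compound 1 to compound 2 and a 3.0-fold lower number (0.47 log units; beyond the scatter) from compound 3 to compound 4, 2.4-fold (0.37 log units) apart, within the scatter of two such steps. The two pairs are therefore consistent with the change carrying over between these two cores, but they do not establish a fixed size for its effect, and they show nothing about any third core.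

As far as these compounds go, it remains open how a carboxylic acid or a longer chain would behave at this same place. From the compounds shown here alone, it is also open whether either group would give similar steps on both cores.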